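A few compounds are considered here, and "the series" means these few. Any claim that something is new, unique, unknown or untested is made for them only; others in the source may bear on it.

Series notes, intraperitoneal dosing in mice. Compound 1 `COc1cc(OC)c(OC)cc1/C=C/COC(=O)/C=C/c1c(OC)ccc(OC)c1OC` is the reference point: in a functional assay on the whole organism (strain Kunming) with Mus musculus as the target, with a stated time of 0.5 h, at a dose of 300 mg/kg by the intraperitoneal route (a higher number here means a weaker effect of the compound at the dose given, a lower number a stronger effect), compound 1 gives 100%. Compound 2 `COc1cc(OC)c(OC)cc1/C=C/COC(=O)/C=C/c1ccccc1C(F)(F)F` keeps the shared core and the ester-linked propenyl chain, changing only the aryl group on the far double-bonded chain carbon. In this assay compound 2 gives 100%, level with compound 1 at the digits shown and within the scatter of it; the two values show no difference between them, and both sit at the upper edge of the read-out.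

Compound 3 `COc1cc(OC)c(OC)cc1/C=C/COC(=O)/C=C/c1ccc(Cl)cc1` has not yet been run. Relative to compound 2 the change is 4-chlorophenyl in place of 2-(trifluoromethyl)phenyl on a double-bonded chain carbon bound to a double-bonded chain carbon. Two measured compounds with unrelated aryl groups have given the same reading, so no step beyond the scatter is expected here; the change from compound 2 to compound 3 is estimated at no change at the digits printed from compound 2 to compound 3 (within the scatter). For compound 3 in this assay the expected value is 100%, with a range from 85% to 100%.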

Compound 3, a percentage reported as activity, at one dose (the size of the read-out at that dose, not a potency): 100%
Compound 3: middle estimate and measured number agree at the digits printed, and the stated range covers the measured number.
By their numbers in this assay, from the lowest: compounds 1, 2 and 3 (each within the scatter of the next).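

In this assay the step reads no change at the digits printed from compound 2 to compound 3 (within the scatter), with 4-chlorophenyl in place of 2-(trifluoromethyl)phenyl on a double-bonded chain carbon bound to a double-bonded chain carbon. This position therefore tolerates a swap of 2-(trifluoromethyl)phenyl for a group with fewer heavy atoms and chlorine in place of fluorine without any difference in the reading, and compound 3 gives 100%, still at the upper edge of the read-out. No measurement in hand bears on the reason for this reading.

A reading at that edge leaves open whether this position can affect the result at all. An amine or a carboxylic acid on the phenyl ring, or an amide in place of the ester link, would test this.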